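Replacing the Acetylpiperidine Arm with a Pyrrolylpropyl Chain

A few compounds are considered here, and "the series" means these few. Any claim that something is new, unique, unknown or untested is made for them only; others in the source may bear on it.

Compound 1 `CCOC(=O)N1CCC(CN2CC[C@H](NC(=O)c3cc(Cl)c(N)cc3OC)[C@H](OC)C2)CC1` gives 377 nM in an assay on COS-7 cells for displacement of a labelled ligand from 5-hydroxytryptamine receptor 4 (Homo sapiens), read by scintillation counting, with a stated time of 30 min; on this read-out lower numbers stand for stronger inhibition and higher numbers for weaker inhibition. Compound 2 `COc1cc(N)c(Cl)cc1C(=O)N[C@H]1CCN(CC2CCN(C(C)=O)CC2)C[C@H]1OC` gives 592 nM in this assay, the higher of the two numbers, and the step of a 1.6-fold higher number from compound 1 to compound 2 (0.20 log units; within the scatter) concerns only the acyl group on the ring. Compound 3 `COc1cc(N)c(Cl)cc1C(=O)N[C@H]1CCN(CCCn2cccc2)C[C@H]1OC` carries 2-(1H-pyrrol-1-yl)ethyl in place of 1-acetylpiperidin-4-yl on a saturated chain carbon bound to an amine nitrogen in a ring. Within the data shown here, no measured step touches the ring itself, so the one step recorded offers little guidance; a step of at most modest size is expected, with the direction uncertain, as a 1.3-fold higher number from compound 2 to compound 3 (0.10 log units; within the scatter). Compound 3 is therefore estimated at 750 nM, within 250 nM to 2200 nM.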

Compound 3, half-maximal inhibitory concentration: 648 nM
Estimate against measurement, compound 3: 1.2-fold (0.06 log units) above; low and high end bracket the measured number.
By their numbers in this assay, from the lowest: compounds 1, 2 and 3 (each within the scatter of the next).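

Replacing the 1-acetylpiperidin-4-yl group with 2-(1H-pyrrol-1-yl)ethyl on a saturated chain carbon bound to an amine nitrogen in a ring stays within the scatter (a 1.1-fold higher number from compound 2 to compound 3 (0.04 log units; within the scatter)), and so does the change from 1-(ethoxycarbonyl)piperidin-4-yl (a 1.7-fold higher number from compound 1 to compound 3 (0.24 log units; within the scatter)). The earlier step altered only the acyl group, whereas these show that exchanging the whole six-membered non-aromatic ring for a five-membered aromatic ring leaves the number within the scatter. No supporting data bear on why this is so.

Going by these compounds, whether a carboxylic acid or a phenyl ring in place of the pyrrole, or a primary amine on the chain, would give a number beyond the scatter remains open.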